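Amine-chain variation on a shared dicyano core: cytotoxicity notes

The source may hold more compounds than are shown below. What is called first, only, known or untested is meant among the compounds shown, and "the series" means these compounds.

Measured compounds:
Compound 1, `CCN(CC)CCn1c(N)c(-c2nc3ccccc3[nH]2)c2nc(C#N)c(C#N)nc21`: in an ADME assay on HEK293 cells (Homo sapiens) for cytotoxicity, read by MTT assay, with a stated time of 48 h (a lower number here means a stronger inhibitor, a higher number a weaker inhibitor), compound 1 gives 12200 nM.
Compound 2, `CN(C)CCCn1c(N)c(-c2nc3ccccc3[nH]2)c2nc(C#N)c(C#N)nc21`: in this assay compound 2 gives 8360 nM.
Compound 3, `CCN(CC)CCCn1c(N)c(-c2nc3cc(Cl)ccc3[nH]2)c2nc(C#N)c(C#N)nc21`: in this assay compound 3 gives 8420 nM.

Compound 1 and compound 2 differ in one place only, ((dimethylamino)methyl in place of diethylamino on a saturated chain carbon, two bonds along the chain from an aromatic nitrogen). In this assay this change gave a 1.5-fold lower number from compound 1 to compound 2 (0.16 log units; within the scatter), so the two numbers sit within the usual scatter of each other. Compound 3 carries a different core; how its core differs from the core of compound 1 is not broken down here, and the values of compound 3 and compound 2 fall within the scatter of each other, as do those of compound 3 and compound 1.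

Compound 4, `CN(C)CCCCn1c(N)c(-c2nc3cc(Cl)ccc3[nH]2)c2nc(C#N)c(C#N)nc21`, is not yet measured. It relates to compound 3 as compound 2 relates to compound 1, through ((dimethylamino)methyl in place of diethylamino on a saturated chain carbon, three bonds along the chain from an aromatic nitrogen). The place line is not identical: in compound 1 to compound 2 the change sits two bonds along the chain from an aromatic nitrogen, in compound 3 to compound 4 three bonds along, so this is the same kind of change rather than the same change. The expectation for compound 4 rests on compound 3 with 8420 nM and on the step of a 1.5-fold lower number from compound 1 to compound 2 (0.16 log units; within the scatter), and the expected step is a 1.2-fold lower number from compound 3 to compound 4 (0.08 log units; within the scatter). Compound 4 is estimated at 7000 nM, with a range expected from 3500 nM to 14000 nM.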

Compound 4, half-maximal inhibitory concentration: 4730 nM
Estimate against measurement, compound 4: 1.5-fold (0.17 log units) above; low and high end bracket the measured number.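

In this assay, (dimethylamino)methyl in place of diethylamino gives a 1.8-fold lower number from compound 3 to compound 4 (0.25 log units; within the scatter), so compound 3 and compound 4 are not separated by this change. Set beside the earlier step on the core of compound 1, the step on the second core shows no difference that can be told from the scatter: the same change on two cores in this assay, a 1.5-fold lower number (0.16 log units; within the scatter) from compound 1 to compound 2 and a 1.8-fold lower number (0.25 log units; within the scatter) from compound 3 to compound 4, 1.2-fold (0.09 log units) apart, within the scatter of two such steps. This supports only a narrow reading: on these two cores the change leaves the number within the scatter, but neither step on its own establishes a real effect, and two pairs do not establish a rule for further cores; the change also sits two bonds along the chain from an aromatic nitrogen in one pair and three bonds along in the other, so it is the same kind of change rather than the same change, and any influence of the core cannot be separated from that of the chain.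

The compounds shown leave open how the series behaves with a cyclic amine such as morpholine, or with a primary amine, at the end of the chain. They also leave open whether the step would hold on a core with fluorine in place of chlorine, or with a still longer chain.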